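Hydroxyethyl amide to methyl ester: a solubility outlook

The source may report more compounds than this note shows. Statements on the series, on what has been measured and on what is new or still open speak of the compounds shown alone.

Compound 1 `c1cc2ccc(CN3CCCCC3)ccc-2c1`: in a physicochemical assay for solubility, with a stated time of 24 h, at pH 2.2 (on this read-out higher numbers stand for higher solubility and lower numbers for lower solubility), compound 1 gives only a limit, > 56 ug/mL.
Compound 2 `O=C(NCCO)c1ccc2ccc(C(=O)c3ccccc3)c-2cc1`: compound 2 gives 14 ug/mL.
Compound 3 `O=C(Cn1ccccc1=O)Nc1cc2cccccc-2c1`: compound 3 gives 4 ug/mL.

Of the two numbers shown, compound 2 stands highest; the nearest is compound 3, whose value lies lower by a gap beyond the usual scatter. One further entry is a limit (the limit of > 56 ug/mL in this assay, at which 1 of the 3 values shown sits). Compound 4 `COC(=O)c1ccc2ccc(C(=O)c3ccccc3)c-2cc1` differs from compound 2 by methoxy in place of (2-hydroxyethyl)amino on a carbonyl carbon. Within the data shown here, no measured pair covers this change, so the expectation rests on the structures alone. A moderate fall in this assay, beyond the scatter, is expected: a 2.8-fold lower number from compound 2 to compound 4 (0.45 log units; beyond the scatter). Compound 4 is therefore estimated at 5 ug/mL, with a range from 1.5 ug/mL to 15 ug/mL.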

Compound 4, solubility: < 1 ug/mL
Compound 4 was reported as a limit; the forecaster's own chance of this, stated with the estimate: 15%; middle value at least 5.0-fold (0.69 log units) away from the limit.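

At this carbonyl carbon, methoxy in place of (2-hydroxyethyl)amino gives an at least 14-fold lower number from compound 2 to compound 4 (1.14 log units; beyond the scatter) in this assay, the only step shown between compounds that differ in one place. Compound 4 is reported only as a limit: the limit of < 1 ug/mL in this assay, at which 1 of the 4 values shown sits. The full size of the step therefore cannot be read, but the read-out clearly responds to the group on this carbonyl carbon. The compounds shown leave open which part of the (2-hydroxyethyl)amino matters. They also leave open how a carboxylic acid, or an amide with a longer chain ending in an amine, would read at the same carbon in this assay.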